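Adding phenoxy to compound 1: expected step

A few compounds are considered here, and "the series" means these few. Any claim that something is new, unique, unknown or untested is made for them only; others in the source may bear on it.

Within the data shown here, in a functional assay on KB-V1 cells (Homo sapiens) for cytotoxicity, read by MTT assay, with a stated time of 72 h (a lower number here means a stronger inhibitor, a higher number a weaker inhibitor), compound 1 `O=C1Nc2ccccc2/C1=N/NC(=S)Nc1ccccc1` gives 1470 nM, and no compound measured so far stands below it beyond the scatter. Compound 3 `COc1ccccc1NC(=S)N/N=C1\C(=O)Nc2ccccc21` gives 2690 nM, and a 1.8-fold higher number from compound 1 to compound 3 (0.26 log units; within the scatter) leaves it level with compound 1. Among the measured compounds shown here, compound 2 `CC(C)NC(=S)N/N=C1\C(=O)Nc2ccccc21` gives 10300 nM, and a 7.0-fold higher number from compound 1 to compound 2 (0.85 log units; beyond the scatter) is the only step here that clears the scatter.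

The next compound, compound 4 `O=C1Nc2ccccc2/C1=N/NC(=S)Nc1ccc(Oc2ccccc2)cc1`, has phenoxy in place of hydrogen on an aromatic carbon of a six-membered aromatic ring of carbon only, para to a large group: phenoxy in place of hydrogen on an aromatic carbon.

For the measured compounds named here, two measured steps bear on this change. The closer one is a 1.8-fold higher number from compound 1 to compound 3 (0.26 log units; within the scatter), which also puts a group in place of hydrogen on the same ring, although methoxy is far smaller than phenoxy. The other, a 7.0-fold higher number from compound 1 to compound 2 (0.85 log units; beyond the scatter), replaces the phenyl group itself, and compound 4 keeps that group, so it gives no reason to expect a loss of that size. Going by the values given here, no measured compound carries a group as large as phenoxy, so the range stays wide. No step beyond the scatter is expected in this assay. The estimated change is a 1.3-fold lower number from compound 1 to compound 4 (0.13 log units; within the scatter). For compound 4 the expected value is 1100 nM, with an estimated range of 350 nM to 3500 nM.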

Compound 4, half-maximal inhibitory concentration: 1670 nM
For compound 4 the middle estimate is 1.5-fold (0.18 log units) below the measured one; the range from low to high includes it.
By their numbers in this assay, from the lowest: compounds 1, 4 and 3 (each within the scatter of the next); then compound 2.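

In this assay, a 1.1-fold higher number from compound 1 to compound 4 (0.06 log units; within the scatter) shows that phenoxy in place of hydrogen, para to a large group, leaves the number level with that of compound 1. Before this result, methoxy in compound 3 was the only group shown on this ring, so it was not known whether a group carrying a whole additional aromatic ring could be placed there without a step beyond the scatter. Across the compounds shown, both additions to the ring, in compound 3 and compound 4, stay within the scatter, while the one step beyond it, a 7.0-fold higher number from compound 1 to compound 2 (0.85 log units; beyond the scatter), replaces the phenyl group itself. Nothing available here accounts for the absence of a step at this position.

From the compounds shown here alone, whether an amine or a carboxylic acid on this same aromatic carbon would also stay level with compound 1 remains open, as does the result for a longer chain such as benzyloxy. Phenoxy on any other carbon of this ring is equally open, so the present reading applies to this one place only.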